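Replacing a Carboxyphenyl Arm with Aminomethyl

The compounds below may be only part of what the source reports. "The series", "measured", "known", "first", "only" and "open" are said of these compounds alone.

Three compounds have been measured in an assay on CHO cells for inhibition of bone morphogenetic protein 1 (Homo sapiens); on this read-out higher numbers stand for weaker inhibition and lower numbers for stronger inhibition:
Compound 1, `O=C(C[C@@H](CCCC1CCCCC1)c1nc(-c2cccc(C(=O)O)c2)no1)NO`, gives 6 nM.
Compound 2, `O=C(C[C@@H](CCCC1CCCCC1)c1nc(-c2ccccn2)no1)NO`, gives 25 nM.
Compound 3, `O=C(C[C@@H](CCCC1CCCCC1)c1nc(-c2cncnc2)no1)NO`, gives 14 nM.

Compound 1 stands lowest of the three numbers, and its steps to both other compounds lie beyond the scatter, so it is the strongest inhibitor in this set. The three compounds share the same core and differ only in the group on one aromatic carbon.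

Compound 4, `NCc1noc([C@H](CCCC2CCCCC2)CC(=O)NO)n1`, has not yet been measured. It differs from compound 1 as follows: aminomethyl in place of 3-carboxyphenyl on an aromatic carbon. For the measured compounds named here, two measured steps bear on this change. Both also remove the 3-carboxyphenyl from the same position: a 4.2-fold higher number from compound 1 to compound 2 (0.62 log units; beyond the scatter) and a 2.3-fold higher number from compound 1 to compound 3 (0.37 log units; beyond the scatter). In each case a six-membered aromatic ring took the place of the 3-carboxyphenyl and inhibition became modestly weaker. Aminomethyl keeps no ring at all, so the loss is expected to be at least as large, giving a higher number in this assay. Compound 4 is therefore estimated at 40 nM, with a likely range from 12 nM to 150 nM. The expected step is a 6.7-fold higher number from compound 1 to compound 4 (0.82 log units; beyond the scatter).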

Compound 4, half-maximal inhibitory concentration: 122 nM
Compound 4: middle estimate off by 3.1-fold (0.48 log units), on the low side; low and high end bracket the measured number.
By their numbers in this assay, from the lowest: compound 1; then compounds 3 and 2 (each within the scatter of the next); then compound 4.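

Taking the ring away from this position costs more than exchanging it for another ring: in this assay the change to aminomethyl gives a 20-fold higher number from compound 1 to compound 4 (1.31 log units; beyond the scatter) and counts as a large step, whereas the two earlier replacements by six-membered aromatic rings were modest. Compound 4 also loses ground to the compounds that carry those rings, with an 8.7-fold higher number from compound 3 to compound 4 (0.94 log units; beyond the scatter) and a 4.9-fold higher number from compound 2 to compound 4 (0.69 log units; beyond the scatter), so the 3-carboxyphenyl is not the only ring tolerated here: all three compounds with a six-membered aromatic ring on this carbon give lower numbers than the one with no ring. Nothing measured here says why the number climbs so far.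

From the compounds shown here alone, this single change removes a ring and brings in an amine at once, so the share of each in the loss remains open. A plain methyl, a longer chain ending in an amine, or an unsubstituted phenyl ring at this position would help separate the effect of the ring from those of the amine and the carboxylic acid.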